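One Added Methyl on the Ring of Compound 3

The source may report more compounds than this note shows. Statements on the series, on what has been measured and on what is new or still open speak of the compounds shown alone.

Three related compounds have been tested in a functional assay on the whole organism for antagonist activity, with Mus musculus as the target; on this read-out lower numbers stand for an effect already at smaller amounts and higher numbers for an effect only at larger amounts of compound. Compound 2 (`CCOC(=O)N(C)CC#CCn1cncc1C`) gives a measured number, 30 mg/kg. Compound 1 (`COC(=O)N(C)C(C)C#CCn1cncc1C`) gives no number but a limit of the assay, > 100 mg/kg. Compound 3 (`CCOC(=O)N(C)C(C)C#CCn1ccnc1`) likewise gives a limit, > 100 mg/kg, which places it at the limit of > 100 mg/kg in this assay, at which 2 of the 3 values shown sit.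

Compound 4 (`CCOC(=O)N(C)C(C)C#CCn1cncc1C`) has methyl in place of hydrogen on an aromatic carbon of compound 3 (methyl in place of hydrogen on an aromatic carbon). Compound 2 carries the same 5-methyl-1H-imidazol-1-yl group and gives 30 mg/kg, so a shift towards smaller doses seems likely. Compound 1 goes against this, with its limit of > 100 mg/kg, so the expectation stays cautious. The expected change is an at least 2.2-fold lower number from compound 3 to compound 4 (0.34 log units; beyond the scatter). For compound 4 the estimated value is 45 mg/kg, with an expected range of 12 mg/kg to 150 mg/kg.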

Compound 4, dose for half-maximal effect: 30 mg/kg
For compound 4 the middle estimate is 1.5-fold (0.18 log units) above the measured one; measured number inside the range.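

In this assay, placing methyl on this aromatic carbon, next to the ring nitrogen, gives an at least 3.3-fold lower number from compound 3 to compound 4 (0.52 log units; beyond the scatter), so the ring methyl matters when the rest of the molecule is that of compound 3. Methyl on the other two sites behaves differently: the chain carbon bound to the triple-bonded carbon gives no change at the digits printed from compound 2 to compound 4 (within the scatter), whereas the carbon bound to the oxygen next to the carbonyl group gives an at least 3.3-fold lower number from compound 1 to compound 4 (0.52 log units; beyond the scatter). Compound 1 and compound 3 each hold a limit of the assay, not a number: the limit of > 100 mg/kg in this assay, at which 2 of the 4 values shown sit.

From the compounds shown here alone, how an ethyl group or an amine on this ring carbon would compare with methyl remains open. So does the effect of a longer chain than ethyl on the oxygen next to the carbonyl group.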